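Replacing a carbamate by a urea on a shared core

The source may hold more compounds than are shown below. What is called first, only, known or untested is meant among the compounds shown, and "the series" means these compounds.

Compound 1, `O=C1NC(c2ccccc2)CN1S(=O)(=O)c1ccc2c(c1)CCCN2`, gives > 20000 nM, a limit of the assay.
Compound 2, `CC(C)COC(=O)N1CCCc2cc(S(=O)(=O)N3CC(c4ccccc4)NC3=O)ccc21`, gives 2750 nM.
Compound 3, `CCCCOC(=O)N1CCCc2cc(S(=O)(=O)N3CC(c4ccccc4)NC3=O)ccc21`, gives 4010 nM.

All three were tested in a functional assay on cells (KATO III cell, Homo sapiens) for antiproliferative activity, read by MTT assay; on this read-out higher numbers stand for weaker inhibition and lower numbers for stronger inhibition. For compound 1 only a limit of the assay is known, which is the limit of > 20000 nM in this assay, at which 1 of the 3 values shown sits. Compound 2 shows the lowest of the two numbers actually measured, with compound 3 nearest at a 1.5-fold higher number from compound 2 to compound 3 (0.16 log units; within the scatter), a gap within the scatter. The steps of an at least 7.2-fold lower number from compound 1 to compound 2 (0.86 log units; beyond the scatter) and an at least 4.9-fold lower number from compound 1 to compound 3 (0.69 log units; beyond the scatter) show that a carbonyl-bearing group on the ring nitrogen of the shared core brings the number well down from the limit.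

Compound 4, `O=C(NC1CCCCC1)N1CCCc2cc(S(=O)(=O)N3CC(c4ccccc4)NC3=O)ccc21`, has not yet been measured. It differs from compound 2 as cyclohexylamino in place of isobutoxy on a carbonyl carbon. Among the compounds with values here, no measured step changes this position in the same way; the nearest evidence is that two different carbamates, compound 2 and compound 3, both sit at similar numbers, and that the chain shape made no difference beyond the scatter. Compound 4 keeps a carbonyl on that ring nitrogen, so its number is expected to stay close to that of compound 2, with a 1.1-fold lower number from compound 2 to compound 4 (0.04 log units; within the scatter) the expected step. For compound 4 the estimate in this assay is 2500 nM, between 800 nM and 8000 nM.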

Compound 4, half-maximal inhibitory concentration: 8920 nM
Compound 4: the middle estimate sits 3.6-fold (0.55 log units) below what was measured, and the stated range ends below it.
By their numbers in this assay, from the lowest: compounds 2 and 3 (each within the scatter of the next); then compound 4. At a limit, above all of these: compound 1.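

In this assay, this carbonyl carbon proves sensitive to the group it carries: cyclohexylamino in place of isobutoxy gives a 3.2-fold higher number from compound 2 to compound 4 (0.51 log units; beyond the scatter), and cyclohexylamino in place of butoxy gives a 2.2-fold higher number from compound 3 to compound 4 (0.35 log units; beyond the scatter). The earlier change of chain, a 1.5-fold higher number from compound 2 to compound 3 (0.16 log units; within the scatter), showed no difference beyond the scatter, whereas going from a carbamate to a urea carrying a cyclohexyl ring does, although this single swap changes both the linking atom and the shape of the group, so the two contributions cannot be separated. A carbonyl-bearing group on the ring nitrogen still goes with a lower number, an at least 2.2-fold lower number from compound 1 to compound 4 (0.35 log units; beyond the scatter), but the size of that step is only a bound, as compound 1 stands at a limit: the limit of > 20000 nM in this assay, at which 1 of the 4 values shown sits.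

The compounds shown leave open whether the rise comes from the urea nitrogen or from the cyclohexyl ring; a butylamino urea and a cyclohexyloxy carbamate would pull these two apart. Also open, as far as these compounds go, is how a simple amide such as acetyl, or a carbamate with a longer chain, would read at this position.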